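Sulfonamide series: 2-ethylphenyl analogue of compound 3

A few compounds are considered here, and "the series" means these few. Any claim that something is new, unique, unknown or untested is made for them only; others in the source may bear on it.

Measured in a functional assay on M21 cells (Homo sapiens) for cytotoxicity, read by sulforhodamine B assay, with a stated time of 48 h; on this read-out lower numbers stand for stronger inhibition and higher numbers for weaker inhibition:
compound 1, `Cc1ccccc1OS(=O)(=O)c1ccc(NC(=O)NCCCCl)cc1`, gives 25000 nM.
compound 2, `O=C(NCCCCl)Nc1ccc(S(=O)(=O)Oc2ccc(O)cc2)cc1`, gives 47000 nM.
compound 3, `Cc1ccccc1NS(=O)(=O)c1ccc(NC(=O)NCCCCl)cc1`, gives > 200000 nM, which is a limit of the assay and not a number.

Compound 3 stands at the top edge of the numbers shown; it is the one compound for which only a limit is known, (the limit of > 200000 nM in this assay, at which 1 of the 3 values shown sits). The two sulfonate esters carry numbers and their step, a 1.9-fold higher number from compound 1 to compound 2 (0.27 log units; within the scatter), is within the scatter. Both steps into the sulfonamide run beyond it: an at least 8.0-fold higher number from compound 1 to compound 3 (0.90 log units; beyond the scatter) and an at least 4.2-fold higher number from compound 2 to compound 3 (0.62 log units; beyond the scatter).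

Compound 4, `CCc1ccccc1NS(=O)(=O)c1ccc(NC(=O)NCCCCl)cc1`, differs from compound 3 by methyl in place of hydrogen on a saturated chain carbon bound to an aromatic carbon. Within the data shown here, none of the measured steps touches this position: the measured changes swap the group on the sulfonyl sulfur or the aryl on the oxygen, and in every one the 2-methylphenyl is kept as it is. No measured step therefore bears directly on the change; what is known is only that compound 3 itself sits beyond the limit and that the sulfonamide is the weaker arrangement in both steps shown.

The expectation for compound 4 is no step beyond the scatter, a step that the limit leaves unreadable from compound 3 to compound 4, with the value most likely reported again as a limit. The estimate for compound 4 is 250000 nM, with a range from 100000 nM to 600000 nM.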

Compound 4, half-maximal inhibitory concentration: > 200000 nM
Compound 4 ended at the assay's limit; the forecaster's own chance of this, stated with the estimate: 80%; the middle value does not contradict the limit.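

Compound 3 and compound 4 both stand at a limit and not at a number, so no step between them can be read: the limit of > 200000 nM in this assay, at which 2 of the 4 values shown sit.

The compounds shown leave open how the 2-ethylphenyl and 2-methylphenyl sulfonamides compare, and whether any sulfonamide of this series gives a number rather than a limit.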